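Swapping Dipropylamino for Dipentylamino at the Chain End

The source may hold more compounds than are shown below. What is called first, only, known or untested is meant among the compounds shown, and "the series" means these compounds.

The measured compounds and their values:
compound 1 `CCCCOc1c(-c2cc(OC)c(OC)c(OC)c2)oc2ccccc2c1=O`: 12800 nM
compound 2 `CCCN(CCC)CCCOc1c(-c2cc(OC)c(OC)c(OC)c2)oc2ccccc2c1=O`: 16800 nM
compound 3 `CCCN(CCC)CCCCOc1c(-c2cc(OC)c(OC)c(OC)c2)oc2ccccc2c1=O`: 11600 nM

All three were tested in a functional assay on PC-3 cells (Homo sapiens) for antiproliferative activity, read by WST assay, with a stated time of 3 days; a higher number here means a weaker inhibitor, a lower number a stronger inhibitor. Compound 1 holds the second highest of the three numbers, but the step to compound 3 a 1.1-fold lower number from compound 1 to compound 3 (0.04 log units; within the scatter) and the step to compound 2 a 1.3-fold higher number from compound 1 to compound 2 (0.12 log units; within the scatter) both lie within the scatter, so the three cannot be told apart on these data. The step from compound 2 to compound 3 a 1.4-fold lower number from compound 2 to compound 3 (0.16 log units; within the scatter) is likewise within the scatter.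

Compound 4 `CCCCCN(CCCCC)CCCCOc1c(-c2cc(OC)c(OC)c(OC)c2)oc2ccccc2c1=O` differs from compound 1 as follows: dipentylamino in place of hydrogen on a saturated chain carbon, four bonds along the chain from an oxygen on an aromatic ring. Within the data shown here, the closest precedent is the step from compound 1 to compound 3, where dipropylamino entered at the same place a 1.1-fold lower number from compound 1 to compound 3 (0.04 log units; within the scatter), with no shift beyond the scatter. Dipentylamino is a larger amine, but nothing among the measured compounds shows that such a change moves the number. A step of no real size is therefore expected, a 1.1-fold lower number from compound 1 to compound 4 (0.05 log units; within the scatter).

Compound 4 is estimated at 11500 nM, with a range from 4500 nM to 30000 nM.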

Compound 4, half-maximal inhibitory concentration: 7900 nM
For compound 4 the middle estimate is 1.5-fold (0.16 log units) above the measured one; the measured number falls inside the stated range.
By their numbers in this assay, from the lowest: compounds 4, 3, 1 and 2 (each within the scatter of the next, the first and the last beyond it).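

Adding dipentylamino on the saturated chain carbon four bonds along the chain from an oxygen on an aromatic ring gives a 1.6-fold lower number from compound 1 to compound 4 (0.21 log units; within the scatter) and exchanging dipropylamino for dipentylamino at that place gives a 1.5-fold lower number from compound 3 to compound 4 (0.17 log units; within the scatter) so the added dipentylamino leaves the number within the scatter of compound 1. In this assay, among these compounds, the first step to pass the scatter is a 2.1-fold lower number from compound 2 to compound 4 (0.33 log units; beyond the scatter) and it is only modest. That step replaces dipropylamino with (dipentylamino)methyl, so the amine and the chain differ together and their contributions cannot be separated.

On these data alone, whether a piperidine or a carboxylic acid at this place would move the number remains open, as does the value of dipentylamino on the chain of compound 2. Nothing measured here explains any of these steps.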